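A few compounds are considered here, and "the series" means these few. Any claim that something is new, unique, unknown or untested is made for them only; others in the source may bear on it.

Measured in a functional assay on HL-60 cells (Homo sapiens) for inhibition, read by MTT assay, with a stated time of 72 h; on this read-out higher numbers stand for weaker inhibition and lower numbers for stronger inhibition:
- compound 1 `Cc1nc(-c2ccccc2)c(C(=O)N2CCN(c3cccc(Cl)c3)CC2)o1`: 39.2 nM
- compound 2 `Cc1ccc(C)c(N2CCN(C(=O)c3oc(C)nc3-c3ccccc3)CC2)c1`: 31.3 nM
- compound 3 `Cc1nc(-c2ccccc2)c(C(=O)N2CCN(c3ccccc3F)CC2)o1`: 147 nM

The highest number of the three belongs to compound 3, at 147 nM. The two steps leading to it are a 3.8-fold higher number from compound 1 to compound 3 (0.57 log units; beyond the scatter) and a 4.7-fold higher number from compound 2 to compound 3 (0.67 log units; beyond the scatter). The remaining step, a 1.3-fold lower number from compound 1 to compound 2 (0.10 log units; within the scatter), shows no separation between the other two compounds.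

The next compound is compound 4 `Cc1nc(-c2ccccc2)c(C(=O)N2CCN(c3ccccc3)CC2)o1`. The structural change is hydrogen in place of fluoro on an aromatic carbon, ortho to a large group, so that 2-fluorophenyl becomes phenyl.

For the measured compounds named here, no measured step makes this exact change, and no measured compound carries the plain phenyl. All three steps exchange the aryl group on the same amine nitrogen, so they bear on it only indirectly. They show that changes there can give a modest step, as in a 4.7-fold higher number from compound 2 to compound 3 (0.67 log units; beyond the scatter), or none beyond the scatter, as in a 1.3-fold lower number from compound 1 to compound 2 (0.10 log units; within the scatter). Here only the fluoro leaves, so a small change is expected, with a slight drift towards the lower numbers of the other two compounds. The expected step is a 1.2-fold lower number from compound 3 to compound 4 (0.09 log units; within the scatter), and no step beyond the scatter is anticipated.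

For compound 4 the estimated value is 120 nM, with an expected range of 45 nM to 320 nM.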

Compound 4, half-maximal inhibitory concentration: 39.1 nM
Compound 4: middle estimate off by 3.1-fold (0.49 log units), on the high side; the whole stated range lies above it.
By their numbers in this assay, from the lowest: compounds 2, 4 and 1 (each within the scatter of the next); then compound 3.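

Hydrogen in place of fluoro gives a 3.8-fold lower number from compound 3 to compound 4 (0.58 log units; beyond the scatter) in this assay and thus shows that this single atom, ortho to a large group, is enough to set compound 3 apart as the weakest of the four compounds. The plain phenyl cannot be separated from the other two aryl groups, with a 1.0-fold lower number from compound 1 to compound 4 (0.00 log units; within the scatter) for hydrogen in place of chloro and a 1.2-fold higher number from compound 2 to compound 4 (0.10 log units; within the scatter) for phenyl in place of 2,5-dimethylphenyl, so neither of those substituted rings moves the number beyond the scatter relative to the unsubstituted ring. Nothing available on this series gives a reason for the step at the fluoro position.

As far as these compounds go, whether the higher number belongs to fluoro alone or to other single groups ortho to a large group stays open, and a chloro, methoxy or trifluoromethyl group at that place on an otherwise plain phenyl would test this. From the compounds shown here alone, it is also open whether the fluoro gives a similar step at the other positions of the ring, and whether the step holds with a different group on the shared core.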